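Dropping the Side Chain: From Compound 3 to Compound 4

The source may hold more compounds than are shown below. What is called first, only, known or untested is meant among the compounds shown, and "the series" means these compounds.

Of the compounds shown here, three sharing one core have been tested in a functional assay on the whole organism (Tail, strain ICR) with Mus musculus as the target, in the tail flick test, with a stated time of 30 min, at a dose of 25 umol/kg by the oral route; on this read-out lower numbers stand for a weaker effect and higher numbers for a stronger effect at the one dose given. Compound 1 `N=C(N)NCCC[C@H](NC(=O)CN(c1nc(Cl)nc2[nH]cnc12)C1CC1)C(=O)OCc1ccccc1` gives 23.2%. Compound 2 `CC[C@H](C)[C@H](NC(=O)CN(c1nc(Cl)nc2[nH]cnc12)C1CC1)C(=O)OCc1ccccc1` gives 41.4%. Compound 3 `NC(=O)CC[C@H](NC(=O)CN(c1ncnc2c1ncn2C1CCCCO1)C1CC1)C(=O)OCc1ccccc1` gives 47%, which is the highest of the three numbers, though its gap to compound 2 lies within the usual scatter and only its gap to compound 1 lies beyond it.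

The next compound, compound 4 `O=C(CN(c1ncnc2c1ncn2C1CCCCO1)C1CC1)NCC(=O)OCc1ccccc1`, is compound 3 with the side chain removed: hydrogen in place of 2-carbamoylethyl on a saturated chain carbon bound to an amide-type nitrogen and a carbonyl carbon.

For the measured compounds named here, one measured step bears on this, loosely: in this assay the read-out was a number 18.2 percentage points higher from compound 1 to compound 2 (beyond the scatter), where one side chain replaced another on the same carbon. Going by the values given here, removing a side chain altogether is a different kind of change, and no measured pair shows it, so the expected step for compound 4 is small and uncertain in direction. The estimate for compound 4 is therefore close to compound 3: in this assay compound 4 is expected to give 40%, with a plausible range from 20% to 60%. Expressed as a step, this estimate means a number 7 percentage points lower from compound 3 to compound 4 (within the scatter).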

Compound 4, a percentage reported as activity, at one dose (the size of the read-out at that dose, not a potency): 55.7%
Compound 4: middle estimate off by 15.7 percentage points, on the low side; low and high end bracket the measured number.
By their numbers in this assay, from the lowest: compound 1; then compounds 2, 3 and 4 (each within the scatter of the next, the first and the last beyond it).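

In this assay putting hydrogen in place of 2-carbamoylethyl on a saturated chain carbon bound to an amide-type nitrogen and a carbonyl carbon gives a number 8.7 percentage points higher from compound 3 to compound 4 (within the scatter) and so leaves the two compounds indistinguishable on this read-out. The earlier step only swapped one side chain for another, whereas this one shows that on this core the carbon can lose its side chain altogether, with the hydrogen-bond donor and acceptor it carries, and the effect at this one dose still cannot be told from that of compound 3. Nothing available here explains why the read-out holds when the side chain goes.

As far as these compounds go, it remains open how a methyl group, or a carboxylic acid or an amine on a longer chain, would read at this carbon. Also open, from the compounds shown here alone, are whether hydrogen would serve equally well on the core of compound 1, and whether compound 3 and compound 4 would stay this close at other doses or at other times after dosing.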